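Swapping a methoxyphenyl for a dichlorophenyl on the imine

A few compounds are considered here, and "the series" means these few. Any claim that something is new, unique, unknown or untested is made for them only; others in the source may bear on it.

Three imines sharing one core have been measured in a functional assay on P388 cells (Mus musculus) for cytotoxicity, read by MTT assay, with a stated time of 72 h; a higher number here means a weaker inhibitor, a lower number a stronger inhibitor. Compound 1 `COc1ccc(/C=N/c2c(C)n(C)n(-c3ccccc3)c2=O)cc1` gives 186000000 nM in this assay, compound 2 `COc1cccc(/C=N/c2c(C)n(C)n(-c3ccccc3)c2=O)c1` gives 105000000 nM, and compound 3 `COc1ccccc1/C=N/c1c(C)n(C)n(-c2ccccc2)c1=O` gives 229000000 nM. Moving the methoxy group around the ring changes little: a 1.8-fold lower number from compound 1 to compound 2 (0.25 log units; within the scatter) and a 1.2-fold higher number from compound 1 to compound 3 (0.09 log units; within the scatter), while a 2.2-fold higher number from compound 2 to compound 3 (0.34 log units; beyond the scatter). Compound 3 therefore shows the highest number of the three, separated from compound 1 by a gap within the scatter and from compound 2 by a gap only modestly beyond it.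

Compound 4 `Cc1c(/N=C/c2ccc(Cl)cc2Cl)c(=O)n(-c2ccccc2)n1C` differs from compound 3 in one place: 2,4-dichlorophenyl in place of 2-methoxyphenyl on a carbon with a double bond to nitrogen. Going by the values given here, no measured step exchanges a methoxy group for chlorine, so the only guide is that the three methoxyphenyl variants stay close to one another in this assay, and the dichlorophenyl analogue is expected to land in the same region. Compound 4 is therefore expected to give about 150000000 nM in this assay, estimated within 40000000 nM to 500000000 nM. This means an expected step of a 1.5-fold lower number from compound 3 to compound 4 (0.18 log units; within the scatter), not beyond the scatter.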

Compound 4, half-maximal inhibitory concentration: 363000000 nM
The estimate for compound 4 lay 2.4-fold (0.38 log units) below the measured number; the range from low to high includes it.
By their numbers in this assay, from the lowest: compounds 2, 1, 3 and 4 (each within the scatter of the next, the first and the last beyond it).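

In this assay, the step of a 1.6-fold higher number from compound 3 to compound 4 (0.20 log units; within the scatter) and the step of a 2.0-fold higher number from compound 1 to compound 4 (0.29 log units; within the scatter) both show that 2,4-dichlorophenyl on a carbon with a double bond to nitrogen cannot be told apart from two of the methoxyphenyl groups. The methoxyphenyl of compound 2 is the exception, with the step of a 3.5-fold higher number from compound 2 to compound 4 (0.54 log units; beyond the scatter) being the only one of the three to pass the scatter, and only modestly. The earlier compounds shown here had varied only where a methoxy group sat, whereas these steps show that two chlorines can take the place of the methoxy group with the number staying in the same very high region, apart from that modest gap to compound 2. The data given here offer no measurement that accounts for these numbers.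

As far as these compounds go, all four compounds carry a substituted phenyl on this carbon, so it remains open whether a ring bearing an amine or a carboxylic acid, or a ring with no substituent at all, would give a much lower number. From the compounds shown here alone, it also remains open how a single chlorine would compare with the two chlorines of compound 4.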